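Moving the Thiophene Attachment Point on a Nucleoside Core

The compounds below may be only part of what the source reports. "The series", "measured", "known", "first", "only" and "open" are said of these compounds alone.

Compound 1, `Nc1nc(N)c2c(-c3ccsc3)cn([C@@H]3O[C@H](CO)[C@@H](O)[C@H]3O)c2n1`, was tested in a functional assay on HepG2 cells (Homo sapiens) for antiproliferative activity, read by XTT assay, with a stated time of 72 h; a lower number here means a stronger inhibitor, a higher number a weaker inhibitor. In this assay compound 1 gives only a limit, > 20000 nM. Compound 2, `O=c1[nH]cnc2c1c(-c1cc3ccccc3o1)cn2[C@@H]1O[C@H](CO)[C@@H](O)[C@H]1O`, also sits at a limit in this assay, > 20000 nM. Compound 3, `Cc1nc(N)c2c(-c3ccsc3)cn([C@@H]3O[C@H](CO)[C@@H](O)[C@H]3O)c2n1`, which carries methyl in place of amino on an aromatic carbon of the shared core, likewise reaches only a limit, > 20000 nM. The step that the two limits leave unreadable from compound 1 to compound 3 therefore cannot be read, because the limit of > 20000 nM in this assay, at which 3 of the 3 values shown sit, holds all three values at the same limit. Compound 1 thus stands nowhere on a numerical scale: all that is known of it is the limit, and the same holds for its two companions.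

Compound 4, `Nc1nc(N)c2c(-c3cccs3)cn([C@@H]3O[C@H](CO)[C@@H](O)[C@H]3O)c2n1`, differs from compound 1 by thiophen-2-yl in place of thiophen-3-yl on an aromatic carbon. Within the data shown here, no measured step bears on this change; the only measured step, the swap of methyl for amino, is itself unreadable. Nothing in the data points to a shift in this assay beyond the scatter, in either direction. Compound 4 is therefore expected to remain at the limit, with an estimated step of a number no higher from compound 1 to compound 4 (the limit leaves the size open) and an expected value of 20000 nM, between 10000 nM and 60000 nM.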

Compound 4, half-maximal inhibitory concentration: > 20000 nM
Compound 4: a limit, no number; the forecaster's own chance of this, stated with the estimate: 85%; the middle value lies on the limit itself.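

Compound 4 gives only a limit in this assay, > 20000 nM. No step can be read between compound 1 and compound 4, because both rest on the same limit rather than on a number: the limit of > 20000 nM in this assay, at which 4 of the 4 values shown sit. The compounds shown leave open whether the thiophene attachment point affects activity in this assay, and how strong any of these compounds really is.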